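This account rests on a few compounds, and the source may have more. Where it says the series, first, only, none or still open, it means among the compounds named here.

Measured so far in a functional assay on A549 cells (Homo sapiens) for inhibition, read by MTT assay, with a stated time of 72 h; a lower number here means a stronger inhibitor, a higher number a weaker inhibitor:
- compound 1 `O=[N+]([O-])c1ccc(-c2nnc(SCCCN3CCN(c4nc5ccccc5o4)CC3)o2)cc1`: 90800 nM
- compound 2 `Brc1ccc(-c2nnc(SCCCN3CCN(c4nc5ccccc5o4)CC3)o2)cc1`: 123000 nM

Compound 2, at 123000 nM, stands level with compound 1, at 90800 nM, within the scatter of repeated measurements. The next compound to be tested is compound 3 `Oc1ccc(-c2nnc(SCCCN3CCN(c4nc5ccccc5o4)CC3)o2)cc1`. It keeps the shared core of compound 2 and alters a single substituent, with hydroxy in place of bromo on an aromatic carbon. The change is from 4-bromophenyl to 4-hydroxyphenyl.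

Among the measured compounds shown here, only one measured step bears on it. That step, a 1.4-fold higher number from compound 1 to compound 2 (0.13 log units; within the scatter), is bromo in place of nitro on an aromatic carbon, and it stays within the scatter. For the measured compounds named here, it offers no direction to carry forward, and no compound with a hydroxy group has been measured yet. No step beyond the scatter is therefore expected in this assay. The expected change is a 1.2-fold lower number from compound 2 to compound 3 (0.09 log units; within the scatter), which is too small to call a real direction. For compound 3 the estimated value is 100000 nM, with an expected range from 50000 nM to 200000 nM.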

Compound 3, half-maximal inhibitory concentration: 181000 nM
Compound 3: middle estimate off by 1.8-fold (0.26 log units), on the low side; the range from low to high includes it.
By their numbers in this assay, from the lowest: compounds 1, 2 and 3 (each within the scatter of the next).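

In this assay, hydroxy in place of bromo, on an aromatic carbon para to a large group, gives a 1.5-fold higher number from compound 2 to compound 3 (0.17 log units; within the scatter), and hydroxy in place of nitro at the same place gives a 2.0-fold higher number from compound 1 to compound 3 (0.30 log units; within the scatter). Among the compounds shown here, a group with a hydrogen-bond donor now stands at this position for the first time, and compound 3 remains level with compound 1 and compound 2, so nitro, bromo and hydroxy do not separate from one another in this assay. No measured evidence bears on why these three groups read alike.

The compounds shown leave open whether any other group at this position, such as an amine, a carboxylic acid or a methoxy group, would give a step beyond the scatter. They also leave open whether a change elsewhere on the shared core, such as a longer chain in the linker that carries the sulfur, would move the numbers in this assay when this position alone does not.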